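This account rests on a few compounds, and the source may have more. Where it says the series, first, only, none or still open, it means among the compounds named here.

Compound 1, with the structure `N#C/C(=C/c1ccc(Cl)cc1)C(=O)c1ccc[nH]1`, is the anchor of this short series. Going by the values given here, in a functional assay on NCI-H460 cells (Homo sapiens) for cytotoxicity, read by MTT assay, with a stated time of 72 h (a lower number here means a stronger inhibitor of growth, a higher number a weaker inhibitor of growth), compound 1 gives 38000 nM, the only plain number recorded here. Compound 2, with the structure `N#C/C(=C/c1ccc(Cl)c(Cl)c1)C(=O)c1ccc[nH]1`, gives in this assay a limit of < 10000 nM, which is the limit of < 10000 nM in this assay, at which 1 of the 2 values shown sits. Among the compounds with values here, the one measured step, an at least 3.8-fold lower number from compound 1 to compound 2 (0.57 log units; beyond the scatter), comes from adding a second chloro; it describes a different change from the one now considered and so bears on it only loosely.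

Compound 3, with the structure `COc1ccc(/C=C(/C#N)C(=O)c2ccc[nH]2)cc1`, differs from compound 1 as follows: methoxy in place of chloro on an aromatic carbon. Within the data shown here, no measured step swaps chloro for methoxy, so there is no basis for expecting a step beyond the scatter in this assay in either direction. Compound 3 is therefore expected to give about 45000 nM, somewhere between 18000 nM and 120000 nM, which would mean a step of a 1.2-fold higher number from compound 1 to compound 3 (0.07 log units; within the scatter).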

Compound 3, concentration for 50% growth inhibition: 24000 nM
Compound 3: the middle estimate sits 1.9-fold (0.27 log units) above what was measured, within the range that was stated.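

Swapping chloro for methoxy on an aromatic carbon, para to a large group, gives a 1.6-fold lower number from compound 1 to compound 3 (0.20 log units; within the scatter) in this assay. The earlier compounds shown here showed only what a second chloro does; this result shows that the chloro already present in compound 1 can give way to a different group of two heavy atoms, one of them a hydrogen-bond acceptor, with no change beyond the scatter. Nothing shown here gives a reason why this swap leaves the number within the scatter.

The compounds shown leave open whether an amine, a carboxylic acid or a longer chain such as butoxy at this same place would also stay within the scatter of compound 1. They also leave open whether a second chloro added to compound 3 would lower the number as it did for compound 1.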